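The source may report more compounds than this note shows. Statements on the series, on what has been measured and on what is new or still open speak of the compounds shown alone.

Measured compounds:
Compound 1 `CNC(=O)c1c(NO)cc(-c2ccc(OC)cc2)oc1=O`: > 20000 nM
Compound 2 `COC(=O)CNC(=O)c1c(NO)cc(-c2ccc(Cl)cc2)oc1=O`: > 20000 nM

In an ADME assay on Huh-7 cells (Homo sapiens) for cytotoxicity, read by a luciferase reporter and WST assay, with a stated time of 3 days (a lower number here means that less compound is tolerated, a higher number that more compound is tolerated), compound 2 gives > 20000 nM, which is a limit of the assay and not a number. Within the data shown here, the only other value shown, for compound 1 in this assay, is also a limit. Compound 2 therefore stands at the ceiling of what this test can report, at the limit of > 20000 nM in this assay, at which 2 of the 2 values shown sit, and cannot be placed in any order against compound 1.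

Compound 3 `COC(=O)CNC(=O)c1c(NO)cc(-c2ccc(OC)cc2)oc1=O` differs from compound 2 in one place: methoxy in place of chloro on an aromatic carbon. The new group is the same one that compound 1 carries on its aromatic ring, and compound 1 also sits at the limit in this assay. With both neighbours on either side of this change sitting at the limit, the expected step in this assay is none beyond the usual scatter, and the most likely outcome is once more a limit. The step expected is a step that the limit leaves unreadable from compound 2 to compound 3, which amounts to no real change. Compound 3 is thus estimated to give 30000 nM, with a range from 15000 nM to 100000 nM.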

Compound 3, half-maximal cytotoxic concentration: > 20000 nM
Compound 3: a limit, no number; the forecaster's own chance of this, stated with the estimate: 85%; the middle value is on the limit's open side.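

No step in this assay can be read among compound 1, compound 2 and compound 3, since each result is a limit and not a number: the limit of > 20000 nM in this assay, at which 3 of the 3 values shown sit.

What stays open is how much of any of these compounds the cells would tolerate, and whether methoxy in place of chloro, or the added methoxycarbonyl, changes that at all.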